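A few compounds are considered here, and "the series" means these few. Any claim that something is new, unique, unknown or untested is made for them only; others in the source may bear on it.

Compound 1 `COc1ccc(NS(=O)(=O)/C=C/c2c(OC)cc(OC)cc2OC)cc1` gives 75 nM in a functional assay on K562 cells (Homo sapiens) for cytotoxicity, read by trypan blue exclusion, with a stated time of 96 h (on this read-out lower numbers stand for stronger inhibition and higher numbers for weaker inhibition), the lower of the two measured numbers. Compound 2 `COc1ccc(NS(=O)(=O)/C=C/c2c(OC)cc(O)cc2OC)cc1` gives 10000 nM, and the step of a 130-fold higher number from compound 1 to compound 2 (2.12 log units; beyond the scatter) goes with hydrogen in place of methyl on an oxygen on an aromatic ring. Compound 3 `COc1cc(OC)c(/C=C/S(=O)(=O)Nc2ccc(OC)c(NC(C)C(=O)O)c2)c(OC)c1` differs from compound 1 by (1-carboxyethyl)amino in place of hydrogen on an aromatic carbon. Within the data shown here, the single measured step concerns a different ring and a different kind of change, so nothing measured bears on this substitution. The direction is therefore open, and compound 3 is expected to give 300 nM (range 50 nM to 3000 nM). That would be an expected 4.0-fold higher number from compound 1 to compound 3 (0.60 log units; beyond the scatter).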

Compound 3, half-maximal inhibitory concentration: 8 nM
The estimate for compound 3 lay 38-fold (1.57 log units) above the measured number; the whole stated range lies above it.
By their numbers in this assay, from the lowest: compound 3; then compound 1; then compound 2.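

In this assay, the aromatic carbon ortho to a methoxy group accepts a sizeable substituent without loss: a 9.4-fold lower number from compound 1 to compound 3 (0.97 log units; beyond the scatter) is a gain beyond the scatter. The only earlier step was a large rise in the number, so this is the first change shown to lower it, and it shows that the core of compound 1 can still improve at this carbon. Nothing available explains this gain. Going by these compounds, it remains open whether a simple amine at this carbon would give a similar number, or whether the carboxylic acid is needed. On these data alone, how a methyl ester or a longer chain would read is equally open.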